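This account rests on a few compounds, and the source may have more. Where it says the series, first, only, none or still open, it means among the compounds named here.

In an ADME assay on HeLa cells (Homo sapiens) for cytotoxicity, read by crystal violet staining, with a stated time of 72 h (a higher number here means that more compound is tolerated, a lower number that less compound is tolerated), compound 1 (`CCOC(=O)c1cc(CCCOc2c(C)cc(-c3noc(C(F)(F)F)n3)cc2C)on1`) gives 17200 nM. Compound 2 (`Cc1cc(-c2noc(C(F)(F)F)n2)cc(C)c1OCCCc1cc(-c2ccccc2)no1`) reads > 100000 nM, which is a limit of the assay and not a number. Compound 3 (`CNC(=O)c1cc(CCCOc2c(C)cc(-c3noc(C(F)(F)F)n3)cc2C)on1`) reads > 100000 nM, again a limit and not a number. Compound 4 (`Cc1cc(-c2noc(C(F)(F)F)n2)cc(C)c1OCCCc1cc(C(=O)N(C)C)no1`) differs from compound 3 by methyl in place of hydrogen on an amide-type nitrogen, which turns methylcarbamoyl into dimethylcarbamoyl. For the measured compounds named here, no measured step makes this exact change. The closest is the swap of ethoxy for methylamino on the carbonyl carbon, which gave an at least 5.8-fold higher number from compound 1 to compound 3 (0.76 log units; beyond the scatter), while phenyl in place of ethoxycarbonyl gave an at least 5.8-fold higher number from compound 1 to compound 2 (0.76 log units; beyond the scatter). With only these steps to go on, no move beyond the scatter is expected, and the estimated step is a number no higher from compound 3 to compound 4 (the limit leaves the size open). Compound 4 is expected at 100000 nM, within an estimated range of 40000 nM to 200000 nM.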

Compound 4, half-maximal cytotoxic concentration: 13200 nM
Compound 4: middle estimate off by 7.6-fold (0.88 log units), on the high side; measured number below the stated range.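

A single methyl in place of hydrogen on the amide-type nitrogen gives an at least 7.5-fold lower number from compound 3 to compound 4 (0.87 log units; beyond the scatter). Dimethylcarbamoyl in place of phenyl gives an at least 7.5-fold lower number from compound 2 to compound 4 (0.87 log units; beyond the scatter), while dimethylamino in place of ethoxy on the carbonyl carbon gives a 1.3-fold lower number from compound 1 to compound 4 (0.11 log units; within the scatter). So an amide here does not by itself raise the tolerated concentration: of the two amides, only the one keeping the amide hydrogen stands high.

Going by these compounds, the true size of the first two steps stays open because each starts from a limit: the limit of > 100000 nM in this assay, at which 2 of the 4 values shown sit. On these data alone, whether a plain amino or an ethylamino group on the carbonyl carbon behaves like methylamino also remains open.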